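Propyl to isopropyl on the ether oxygen

A few compounds are considered here, and "the series" means these few. Any claim that something is new, unique, unknown or untested is made for them only; others in the source may bear on it.

In a functional assay on A549 cells (Homo sapiens) for cytotoxicity, with a stated time of 48 h (a higher number here means a weaker inhibitor, a lower number a stronger inhibitor), compound 3 `CCCOc1ccc2oc(/C=C/[S+](C)[O-])cc(=O)c2c1` gives 1100 nM. This lies within the scatter of both other measured compounds: compound 2 `CC(C)CCOc1ccc2oc(/C=C/[S+](C)[O-])cc(=O)c2c1` gives 1000 nM, and compound 1 `C[S+]([O-])/C=C/c1cc(=O)c2cc(F)ccc2o1` gives 2100 nM. Compound 4 `CC(C)Oc1ccc2oc(/C=C/[S+](C)[O-])cc(=O)c2c1` has isopropyl in place of propyl on an oxygen on an aromatic ring. Within the data shown here, changing the alkyl chain gave a 1.1-fold higher number from compound 2 to compound 3 (0.04 log units; within the scatter), the closest precedent. Replacing fluoro gave larger steps: a 1.9-fold lower number from compound 1 to compound 3 (0.28 log units; within the scatter), and a 2.1-fold lower number from compound 1 to compound 2 (0.32 log units; beyond the scatter), the only one beyond the scatter. Since the chain change stayed within the scatter, no step beyond the scatter is expected here: the expected step is no change at the digits printed from compound 3 to compound 4 (within the scatter). For compound 4 the estimated value is 1100 nM, with an expected range of 600 nM to 2000 nM.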

Compound 4, half-maximal inhibitory concentration: 1500 nM
Compound 4: the middle estimate sits 1.4-fold (0.13 log units) below what was measured; the measured number falls inside the stated range.
By their numbers in this assay, from the lowest: compounds 2, 3, 4 and 1 (each within the scatter of the next, the first and the last beyond it).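

In this assay, isopropyl in place of propyl on the oxygen stays within the scatter (a 1.4-fold higher number from compound 3 to compound 4 (0.13 log units; within the scatter)), as does isopropyl in place of isopentyl (a 1.5-fold higher number from compound 2 to compound 4 (0.18 log units; within the scatter)), so propyl, isopropyl and isopentyl on this oxygen are not separated here. Isopropoxy in place of fluoro also stays within the scatter (a 1.4-fold lower number from compound 1 to compound 4 (0.15 log units; within the scatter)), so compound 2 alone among the ethers lies beyond the scatter of compound 1. No measurement available here bears on the reason for these small steps.

Still open, going by these compounds, is whether a longer chain, such as octyl, or an amine at the end of the chain on this oxygen would give a step beyond the scatter.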